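The compounds below may be only part of what the source reports. "The series", "measured", "known", "first", "only" and "open" are said of these compounds alone.

Compound 1 `CN(C)C(=O)c1cc2cnc(Nc3ccc(C(=O)NCCCN=C=S)cc3F)nc2n1C1CCCC1`, compound 2 `CN(C)C(=O)c1cc2cnc(Nc3ccc(C(=O)NCCCCN=C=S)cc3F)nc2n1C1CCCC1` and compound 3 `CN(C)C(=O)c1cc2cnc(Nc3ccc(C(=O)NCCCCCCN=C=S)cc3F)nc2n1C1CCCC1` share one core and differ only in the length of a saturated chain attached to it. In a functional assay on NCI-H1299 cells (Homo sapiens) for inhibition, read by CCK-8 assay, with a stated time of 72 h, tested at 10 uM (a lower number here means a weaker effect, a higher number a stronger effect of the compound at the concentration tested), compound 1 gives 78.5%, compound 2 gives 78.9% and compound 3 gives 77.6%. Going from compound 1 to compound 2 means (a group of 4 heavy atoms (2 carbon, 1 nitrogen, 1 sulfur; no ring) in place of a group of 3 heavy atoms (1 carbon, 1 nitrogen, 1 sulfur; no ring), on a saturated chain carbon, three bonds along the chain from an amide-type nitrogen); this made a step of a number 0.4 percentage points higher from compound 1 to compound 2 (within the scatter). Compound 4 `CN(C)C(=O)c1cc2cnc(Nc3ccc(C(=O)NCCCCCCCN=C=S)cc3F)nc2n1C1CCCC1` arises from compound 3 through (a group of 4 heavy atoms (2 carbon, 1 nitrogen, 1 sulfur; no ring) in place of a group of 3 heavy atoms (1 carbon, 1 nitrogen, 1 sulfur; no ring), on a saturated chain carbon, six bonds along the chain from an amide-type nitrogen). The two cores differ by a group of 6 heavy atoms (4 carbon, 1 nitrogen, 1 sulfur; no ring) in place of a group of 3 heavy atoms (1 carbon, 1 nitrogen, 1 sulfur; no ring), on a saturated chain carbon, three bonds along the chain from an amide-type nitrogen, so the new group sits six bonds along the chain from an amide-type nitrogen instead of three bonds, which makes it the same kind of change, not the same. The step from compound 3 to compound 4 in this assay is expected to be a number 0.4 percentage points higher from compound 3 to compound 4 (within the scatter), beside the earlier one. This expectation rests on the step of a number 0.4 percentage points higher from compound 1 to compound 2 (within the scatter) and on the near-equal values of all three measured compounds. Compound 4 is therefore estimated to give 78%, likely between 70% and 85%.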

Compound 4, a percentage reported as inhibition, at one concentration (the size of the read-out at that concentration, not a potency): 35.8%
For compound 4 the middle estimate is 42.2 percentage points above the measured one, and the stated range ends above it.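

In this assay, lengthening the chain does not behave the same way on every core, so a step seen on a shorter chain cannot simply be carried over to a longer one: the same change on two cores in this assay, a number 0.4 percentage points higher (within the scatter) from compound 1 to compound 2 and a number 41.8 percentage points lower (beyond the scatter) from compound 3 to compound 4, 42.2 percentage points apart, beyond the scatter of two such steps
The comparison with a larger extension of the chain says the same: the same change on two cores in this assay, a number 0.9 percentage points lower (within the scatter) from compound 1 to compound 3 and a number 43.1 percentage points lower (beyond the scatter) from compound 2 to compound 4, 42.2 percentage points apart, beyond the scatter of two such steps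
Compound 4 stands apart from all three shorter chains, with a number 41.8 percentage points lower from compound 3 to compound 4 (beyond the scatter), a number 43.1 percentage points lower from compound 2 to compound 4 (beyond the scatter) and a number 42.7 percentage points lower from compound 1 to compound 4 (beyond the scatter), but these steps show only that the effect is lost somewhere along the chain, not why it is lost.

What the compounds shown leave open is whether a longer chain would keep this lower value or fall further. They also leave open whether an amine at the chain end would behave the same way.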